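Chloro Substitution on the Aryl Ring and Whole-Animal Inhibition

The source may report more compounds than this note shows. Statements on the series, on what has been measured and on what is new or still open speak of the compounds shown alone.

Compound 1 `O=C(O)c1cnc(-c2ccccc2)[nH]c1=O` and compound 2 `O=C(O)c1cnc(-c2ccc(Cl)cc2)[nH]c1=O` share one core, while compound 3 `CCOC(=O)c1cnc(-c2ccccc2OCC)[nH]c1=O` is built on another; the difference between the two cores is not broken down here. In a functional assay on the whole organism (strain Sprague-Dawley) for inhibition, with Rattus norvegicus as the target, with a stated time of 10 min (a lower number here means that less compound is needed, a higher number that more compound is needed for the effect), compound 1 gives 50 mg/kg, compound 2 gives 5 mg/kg and compound 3 gives 2 mg/kg. Between compound 1 and compound 2 the change is chloro in place of hydrogen on an aromatic carbon, and it brought a 10-fold lower number from compound 1 to compound 2 (1.00 log units; beyond the scatter). Compound 4 `CCOC(=O)c1cnc(-c2cc(Cl)ccc2OCC)[nH]c1=O` has not been measured; it differs from compound 3 by chloro in place of hydrogen on an aromatic carbon. This is the same kind of change as that from compound 1 to compound 2, but not the same one: there the chloro sits para to a large group, here it sits meta to a large group and para to an ethoxy group. Within the data shown here, since compound 3 already gives 2 mg/kg and the only measured chloro step is a 10-fold lower number from compound 1 to compound 2 (1.00 log units; beyond the scatter), a smaller step is expected for compound 4, namely a 2.9-fold lower number from compound 3 to compound 4 (0.46 log units; beyond the scatter). Compound 4 is therefore estimated to give 0.7 mg/kg in this assay, most likely between 0.2 mg/kg and 2.5 mg/kg.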

Compound 4, dose for 50% inhibition: 0.5 mg/kg
For compound 4 the middle estimate is 1.4-fold (0.15 log units) above the measured one, and the stated range covers the measured number.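

In this assay the chloro change again lowers the number, with a 4.0-fold lower number from compound 3 to compound 4 (0.60 log units; beyond the scatter), so the direction seen on one core also holds on the other. The two steps cannot be told apart in size, even though the pairs differ in their core and in where the chloro sits: the same change on two cores in this assay, a 10-fold lower number (1.00 log units; beyond the scatter) from compound 1 to compound 2 and a 4.0-fold lower number (0.60 log units; beyond the scatter) from compound 3 to compound 4, 2.5-fold (0.40 log units) apart, within the scatter of two such steps. This rests on just two pairs, so it does not show that the step would carry over to a further core or to another place on the aromatic ring, and it gives no reason why the number falls.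

The compounds shown leave open whether a bromo or a methyl group in place of the chloro would lower the number in the same way. They also leave open whether the chloro step would hold with an amide in place of the ethyl ester, or with a longer alkoxy chain in place of the ethoxy group.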